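The compounds below may be only part of what the source reports. "The series", "measured", "known", "first", "only" and "open" are said of these compounds alone.

The two measured compounds share one core and differ only in the group on the oxygen on a saturated carbon. Compound 1 `Cc1nn(-c2ncnc3nc[nH]c23)c2c1C(OC(=O)c1ccc(F)cc1)CC(=O)N2` carries a (4-fluorophenyl)carbonyl there, and in a functional assay on HEK293 cells for agonist activity at G-protein coupled receptor 39 (Homo sapiens), read by scintillation proximity assay and inositol phosphate accumulation, with a stated time of 75 min (a higher number here means that more compound is needed for the effect, a lower number that less compound is needed), compound 1 gives 245 nM. Compound 2 `CCCCCCCCOC1CC(=O)Nc2c1c(C)nn2-c1ncnc2nc[nH]c12` carries octyl in its place, and in this assay compound 2 gives 388 nM. Among the compounds with values here, compound 2 thus holds the higher of the two numbers, but its only neighbour is compound 1, and the step of a 1.6-fold higher number from compound 1 to compound 2 (0.20 log units; within the scatter) leaves the two indistinguishable. Compound 3 `Cc1nn(-c2ncnc3nc[nH]c23)c2c1C(OCC(C)C)CC(=O)N2` keeps the oxygen of compound 2 but shortens what hangs on it: isopropyl in place of heptyl on a saturated chain carbon bound to an oxygen on a saturated carbon. Within the data shown here, no measured step concerns a change of this kind; the one step that exists, from compound 1 to compound 2, put octyl in place of (4-fluorophenyl)carbonyl and stayed within the scatter. With nothing pointing in either direction, the number for compound 3 is expected to stay close to that of compound 2, and the expected step of a 1.1-fold higher number from compound 2 to compound 3 (0.03 log units; within the scatter) is set at essentially nothing beyond the scatter. Compound 3 is therefore estimated at 420 nM, within a range from 150 nM to 1200 nM.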

Compound 3, half-maximal effective concentration: 111 nM
Estimate against measurement, compound 3: 3.8-fold (0.58 log units) above; the measured number lies below the stated range.
By their numbers in this assay, from the lowest: compound 3; then compounds 1 and 2 (each within the scatter of the next).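

The group on the oxygen on a saturated carbon does affect the number in this assay: with isopropyl in place of heptyl on the saturated chain carbon, the result is a 3.5-fold lower number from compound 2 to compound 3 (0.54 log units; beyond the scatter). Within the data shown here, this is the first change at this position to go beyond the scatter, and it shows that the alkyl chain itself matters, not merely whether an alkyl group or a (4-fluorophenyl)carbonyl is present. The comparison with the carbonyl compound points the same way, since isobutyl in place of (4-fluorophenyl)carbonyl gives a 2.2-fold lower number from compound 1 to compound 3 (0.34 log units; beyond the scatter), whereas octyl in that place gave a 1.6-fold higher number from compound 1 to compound 2 (0.20 log units; within the scatter), and no evidence is available to explain this difference between the two chains.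

Since octyl and isobutyl differ in both length and branching, these compounds cannot separate the two, and an unbranched butyl on the same oxygen would bear directly on that question. From the compounds shown here alone, it also remains open whether the number keeps falling with still smaller groups such as ethyl or methyl, or whether a ring such as cyclopropylmethyl or an amine at the end of the chain would be tolerated there.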